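Triazole side-chain variation on a shared core

The compounds below may be only part of what the source reports. "The series", "measured", "known", "first", "only" and "open" are said of these compounds alone.

compound 1 `Cc1ccc(S(=O)(=O)NCc2cn(C[C@H](O)[C@H]3OC(=O)C(OCc4ccccc4)=C3OCc3ccccc3)nn2)cc1`: 14400 nM
compound 2 `O=C1O/C(=C\Cn2cc(-c3cc(F)cc(F)c3)nn2)C(OCc2ccccc2)=C1OCc1ccccc1`: 17700 nM

In a functional assay on HeLa cells (Homo sapiens) for antiproliferative activity, read by MTT assay, with a stated time of 72 h (on this read-out higher numbers stand for weaker inhibition and lower numbers for stronger inhibition), compound 1 gives 14400 nM and compound 2 gives 17700 nM. The two values lie within the usual scatter of each other, so no order between them can be read. Compound 3 `CCCCc1cn(C[C@H](O)[C@H]2OC(=O)C(OCc3ccccc3)=C2OCc2ccccc2)nn1` is not yet measured in this assay. It differs from compound 1 in one place: propyl in place of ((4-methylphenyl)sulfonyl)amino on a saturated chain carbon bound to an aromatic carbon. Among the compounds with values here, no measured pair shows this change, so its size is unknown. The expected step is a 1.0-fold higher number from compound 1 to compound 3 (0.02 log units; within the scatter), within the scatter, with no clear direction. Compound 3 is estimated at 15000 nM, in the range 5000 nM to 45000 nM.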

Compound 3, half-maximal inhibitory concentration: 18100 nM
Compound 3: middle estimate off by 1.2-fold (0.08 log units), on the low side, within the range that was stated.
By their numbers in this assay, from the lowest: compounds 1, 2 and 3 (each within the scatter of the next).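

At the saturated chain carbon bound to an aromatic carbon, propyl in place of ((4-methylphenyl)sulfonyl)amino gives a 1.3-fold higher number from compound 1 to compound 3 (0.10 log units; within the scatter) in this assay as a step within the scatter. In this single pair, the aromatic ring, hydrogen-bond donor and hydrogen-bond acceptors of the leaving group can all go without the value leaving the scatter, so the position shows no dependence on them here. Going by these compounds, whether an amine, a carboxylic acid or a longer chain at this place would give a step beyond the scatter stays open. No evidence at hand accounts for this result.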